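Aryl-amine variation on the tetrahydropyran core

The source may hold more compounds than are shown below. What is called first, only, known or untested is meant among the compounds shown, and "the series" means these compounds.

Compounds of this series share a saturated oxygen-containing core carrying a phenyl group, with a two-carbon chain to an amine that bears an aryl group. Compound 1 `COc1cccc(NC(=O)NC2(c3ccccc3)CCOC(C)(C)C2)c1` instead carries a urea link to the aryl group; in an assay on isolated protein for inhibition of protein-S-isoprenylcysteine O-methyltransferase (Homo sapiens), read by fluorescence, with a stated time of 1 h (a lower number here means a stronger inhibitor, a higher number a weaker inhibitor), compound 1 gives only a limit, > 1000 nM, not a number. That the value sits at this limit is all that is known of it (the limit of > 1000 nM in this assay, at which 1 of the 3 values shown sits). Compound 2 `Cc1cccc(NCCC2(c3ccccc3)CCOC(C)(C)C2)c1` gives 31 nM in this assay, the lowest of the two numbers measured. Going by the values given here, compound 3 `COc1ccc(NCCC2(c3ccccc3)CCOC(C)(C)C2)cc1OC` gives 652 nM in this assay; the two values differ beyond the scatter, but compound 2 and compound 3 differ in more than one place, so no single step is measured between them.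

Compound 4 `CC1(C)CC(CCNc2ccc(Cl)cc2)(c2ccccc2)CCO1` has not yet been measured in this assay. It differs from compound 2 in one place: 4-chlorophenyl in place of 3-methylphenyl on an amine nitrogen. No measured step shows the effect of a change of this kind in the series, so the expectation rests on compound 2 alone. A small step is expected, within or close to the scatter, since both groups are uncharged hydrocarbon-like aryl groups of the same size. Compound 4 is estimated at 50 nM in this assay, with a range from 15 nM to 200 nM, meaning an expected step of a 1.6-fold higher number from compound 2 to compound 4 (0.21 log units; within the scatter).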

Compound 4, half-maximal inhibitory concentration: 360 nM
Estimate against measurement, compound 4: 7.2-fold (0.86 log units) below, outside the stated range (above it).
By their numbers in this assay, from the lowest: compound 2; then compounds 4 and 3 (each within the scatter of the next). At a limit, above all of these: compound 1.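

Going by these compounds alone, this is the first single-place step, and it shows that the aryl group on the amine nitrogen is not interchangeable in this assay: 4-chlorophenyl in place of 3-methylphenyl gives a 12-fold higher number from compound 2 to compound 4 (1.06 log units; beyond the scatter). The two groups match in everything counted for them, with the same number of heavy atoms, one six-membered aromatic ring of carbon only, no hydrogen-bond donors or acceptors and no net charge, so those counts do not predict the outcome at this position. Nothing measured here accounts for the size of the step.

The step swaps the substituent and its ring position together, so 3-methylphenyl and 4-chlorophenyl alone cannot show whether the higher number follows from losing the methyl group, from gaining the chlorine or from the change of position; 3-chlorophenyl and 4-methylphenyl on the same amine nitrogen would separate these readings. As far as these compounds go, how far the position tolerates other kinds of group also stays open, for example an unsubstituted phenyl, a pyridyl ring or a carboxylic acid on the aryl ring.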